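The source may hold more compounds than are shown below. What is called first, only, known or untested is meant among the compounds shown, and "the series" means these compounds.

Measured so far in an assay on cells for activation of Cystic fibrosis transmembrane conductance regulator (Homo sapiens), read by fluorescence, with stated times of 10 min and 12 s; a lower number here means that less compound is needed, a higher number that more compound is needed for the effect:
compound 1 `CCN(CC)c1nc(Nc2ccc(C(=O)O)cc2)nc(OC(C(F)(F)F)C(F)(F)F)n1` gives 900 nM;
compound 2 `CCN(CC)c1nc(Nc2cccc(F)c2)nc(OCC(F)(F)C(F)F)n1` gives 1600 nM;
compound 3 `CCN(CC)c1nc(Nc2cccc([N+](=O)[O-])c2)nc(OCC(F)(F)C(F)F)n1` gives 1200 nM.

Compound 3 stands second highest of the three, with compound 1 and compound 2 on either side of it, both within the scatter. Compound 4 `CCN(CC)c1nc(Nc2ccc(C(=O)O)cc2)nc(OCC(F)(F)C(F)F)n1` is not yet measured. The change is 4-carboxyphenyl in place of 3-nitrophenyl on a nitrogen on an aromatic ring. For the measured compounds named here, only one measured step touches the group on this nitrogen: a 1.3-fold lower number from compound 2 to compound 3 (0.12 log units; within the scatter), within the scatter. The entering 4-carboxyphenyl group is present in compound 1, whose core differs elsewhere from that of compound 3, and compound 1 sits within the scatter of compound 3. Going by the values given here, no measured step covers the exchange of one ring substituent pattern for the other on this nitrogen. The expected step of a 1.2-fold lower number from compound 3 to compound 4 (0.08 log units; within the scatter) is none beyond the scatter in this assay. Compound 4 is estimated at 1000 nM, range 400 nM to 2500 nM.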

Compound 4, half-maximal effective concentration: 2500 nM
Estimate against measurement, compound 4: 2.5-fold (0.40 log units) below; measured number inside the range.
By their numbers in this assay, from the lowest: compounds 1, 3, 2 and 4 (each within the scatter of the next, the first and the last beyond it).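

In this assay, for the compounds shown here, 4-carboxyphenyl on this nitrogen gives the first exchange here to pass the scatter, though modestly (a 2.1-fold higher number from compound 3 to compound 4 (0.32 log units; beyond the scatter)). The same group in place of 3-fluorophenyl stays within it (a 1.6-fold higher number from compound 2 to compound 4 (0.19 log units; within the scatter)), so the outcome depends on the group that leaves. With 4-carboxyphenyl held, the group on the oxygen also counts: 2,2,3,3-tetrafluoropropyl in place of 2,2,2-trifluoro-1-(trifluoromethyl)ethyl gives a modest step beyond the scatter (a 2.8-fold higher number from compound 1 to compound 4 (0.44 log units; beyond the scatter)). Open, from the compounds shown here alone, is how an amide in place of the carboxylic acid would read, and whether the oxygen step holds with 3-nitrophenyl on the nitrogen. Nothing measured here gives a reason for these steps.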